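The source may hold more compounds than are shown below. What is called first, only, known or untested is meant among the compounds shown, and "the series" means these compounds.

Compound 3 `Clc1ccc(-c2nc(-c3c[nH]c4ccccc34)co2)cc1` stands second highest of the three numbers in a functional assay on MCF7 cells (Homo sapiens) for cytotoxicity, read by MTT assay, with a stated time of 48 h; a higher number here means a weaker inhibitor, a lower number a stronger inhibitor: compound 3 gives 410000 nM. Its nearest neighbour is compound 1 `Cc1nc(-c2c[nH]c3ccccc23)co1`, which in this assay gives 802000 nM; the two lie within the scatter, as a 2.0-fold lower number from compound 1 to compound 3 (0.29 log units; within the scatter) shows. Furthest from it is compound 2 `c1ccc2c(-c3coc(-c4ccncc4)n3)c[nH]c2c1`, which in this assay gives 54900 nM; here a 7.5-fold higher number from compound 2 to compound 3 (0.87 log units; beyond the scatter) lies beyond the scatter, as does a 15-fold lower number from compound 1 to compound 2 (1.16 log units; beyond the scatter).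

Compound 4 `C=Cc1nc(-c2c[nH]c3ccccc23)co1` differs from compound 3 in one place: vinyl in place of 4-chlorophenyl on an aromatic carbon. The vinyl that enters is a small group, as methyl is, and a 2.0-fold lower number from compound 1 to compound 3 (0.29 log units; within the scatter) shows that exchanging methyl for 4-chlorophenyl on this aromatic carbon moved the number only within the scatter. Among the measured compounds shown here, the one step beyond the scatter, a 15-fold lower number from compound 1 to compound 2 (1.16 log units; beyond the scatter), concerns pyridin-4-yl, which neither compound 3 nor compound 4 carries. For the measured compounds named here, no step with vinyl itself is known. Compound 4 is therefore expected to sit near compound 3, with a 1.6-fold higher number from compound 3 to compound 4 (0.20 log units; within the scatter) expected to stay within the scatter. The estimate for compound 4 in this assay is 650000 nM, with a range from 250000 nM to 2000000 nM.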

Compound 4, half-maximal inhibitory concentration: 103000 nM
The estimate for compound 4 lay 6.3-fold (0.80 log units) above the measured number; the whole stated range lies above it.
By their numbers in this assay, from the lowest: compounds 2 and 4 (each within the scatter of the next); then compounds 3 and 1 (each within the scatter of the next).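

At this position, size alone does not set the number in this assay: methyl and 4-chlorophenyl had stayed within the scatter of each other, yet vinyl, which has no ring, separates from both, with a 4.0-fold lower number from compound 3 to compound 4 (0.60 log units; beyond the scatter) and a 7.8-fold lower number from compound 1 to compound 4 (0.89 log units; beyond the scatter). A ring on this aromatic carbon is also not needed to reach the level of the pyridin-4-yl group, since a 1.9-fold higher number from compound 2 to compound 4 (0.27 log units; within the scatter) leaves those two compounds indistinguishable. Nothing available explains why vinyl departs from methyl here.

The compounds shown leave open whether the double bond of vinyl matters, which ethyl on the same carbon could show. They also leave open how an amine or a carboxylic acid at this place would compare with vinyl and pyridin-4-yl.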